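Swapping Sulfur for Oxygen on the Amine Nitrogen

The source may hold more compounds than are shown below. What is called first, only, known or untested is meant among the compounds shown, and "the series" means these compounds.

Among the measured compounds shown here, in a functional assay on HeLa cells (Homo sapiens) for inhibition, read by CCK-8 assay, with a stated time of 48 h (on this read-out higher numbers stand for weaker inhibition and lower numbers for stronger inhibition), compound 2 `Cc1ccc(-c2ccsc2S(=O)(=O)NCCNC(=S)Nc2ccc([N+](=O)[O-])cc2)c(Oc2ccc(O)c(O)c2)c1` gives 6800 nM, the only true number so far. Compound 1 `Cc1ccc(-c2ccsc2S(=O)(=O)NCCNC(=O)Nc2ccc([N+](=O)[O-])cc2)c(Oc2ccc(O)c(O)c2)c1` gives > 20000 nM, and this value is a limit. For the measured compounds named here, the one measured step, an at least 2.9-fold lower number from compound 1 to compound 2 (0.46 log units; beyond the scatter), lies beyond the scatter and puts a sulfur-bearing group in place of an oxygen-bearing one on an amine nitrogen.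

Compound 3 `Cc1ccc(-c2ccsc2S(=O)(=O)NCCNC(=O)Nc2cccc([N+](=O)[O-])c2)c(Oc2ccc(O)c(O)c2)c1` has not yet been measured. Its change is a group of 12 heavy atoms (7 carbon, 2 nitrogen, 3 oxygen; one six-membered aromatic ring of carbon only) in place of a group of 12 heavy atoms (7 carbon, 2 nitrogen, 2 oxygen, 1 sulfur; one six-membered aromatic ring of carbon only), on an amine nitrogen. The (3-nitrophenyl)carbamoyl group enters on an amine nitrogen whose other neighbours are a saturated chain carbon. Sulfur thus gives way to oxygen, the reverse of the measured exchange, although the entering group is not the one carried by compound 1. Going by the values given here, no measured step covers that remaining difference alone.

Among the compounds with values here, with an at least 2.9-fold lower number from compound 1 to compound 2 (0.46 log units; beyond the scatter) as the only guide, a move toward weaker inhibition is expected in this assay, of similar size to that step and beyond the scatter. The expected change is a 2.9-fold higher number from compound 2 to compound 3 (0.47 log units; beyond the scatter), and a result reported only as a limit would fit this expectation. Compound 3 is estimated at 20000 nM, within a range of 8000 nM to 50000 nM.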

Compound 3, half-maximal inhibitory concentration: > 20000 nM
Compound 3 gave a limit, no number; the forecaster's own chance of this, stated with the estimate: 55%; the middle value sits exactly at the limit.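

In this assay, the (3-nitrophenyl)carbamoyl group on the amine nitrogen, in place of the sulfur-bearing group of compound 2, gives an at least 2.9-fold higher number from compound 2 to compound 3 (0.46 log units; beyond the scatter), a step that rests on a limit rather than on a true number. Among the compounds shown, the oxygen-bearing group now goes with a limit on both the 4-nitrophenyl of compound 1 and the 3-nitrophenyl of compound 3, and none goes against this, although compound 2 is the only sulfur-bearing compound behind the comparison. The two oxygen-bearing compounds end at one and the same point of the read-out: the limit of > 20000 nM in this assay, at which 2 of the 3 values shown sit.

As far as these compounds go, the two limits leave the step from compound 1 to compound 3 unreadable, so the effect of 3-nitrophenyl in place of 4-nitrophenyl stays unknown, and the step from compound 2 to compound 3 cannot separate that change from the exchange of sulfur for oxygen. From the compounds shown here alone, it also remains open how the sulfur-bearing group would read with 3-nitrophenyl, and how an amine or a carboxylic acid in place of the nitro group, or a longer chain in place of the saturated chain, would read.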